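Swapping an aryl for a benzyl on the ring nitrogen

The compounds below may be only part of what the source reports. "The series", "measured", "known", "first", "only" and "open" are said of these compounds alone.

Of the compounds shown here, three have so far been tested in a functional assay on MCF7 cells (Homo sapiens) for antiproliferative activity, read by MTT assay, with a stated time of 48 h; on this read-out lower numbers stand for stronger inhibition and higher numbers for weaker inhibition. Compound 1 `COc1cc(/C=N/c2c(C#N)ncn2-c2ccc(F)cc2)cc(OC)c1OC` gives 8320 nM. Compound 3 `COc1cc(/C=N/c2c(C#N)ncn2Cc2ccc(F)cc2)cc(OC)c1OC` carries a single change relative to compound 1, (4-fluorobenzyl in place of 4-fluorophenyl on an aromatic nitrogen). Compound 3 gives 9040 nM; the step is a 1.1-fold higher number from compound 1 to compound 3 (0.04 log units; within the scatter). Compound 2 `N#Cc1ncn(-c2ccc(F)cc2)c1/N=C/c1ccc([N+](=O)[O-])cc1` has a different core, and the difference between the two cores is not broken down here. In this assay compound 2 gives 9100 nM. All three values lie close together, so none of the three can be singled out.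

Compound 4 `N#Cc1ncn(Cc2ccc(F)cc2)c1/N=C/c1ccc([N+](=O)[O-])cc1` has not yet been measured. It differs from compound 2 by the same change seen before: 4-fluorobenzyl in place of 4-fluorophenyl on an aromatic nitrogen. Among the compounds with values here, the only guide is the pair that begins at compound 1, where the step stayed within the scatter. Compound 4 is therefore expected to remain close to compound 2 because compound 2 gives 9100 nM and the earlier step was a 1.1-fold higher number from compound 1 to compound 3 (0.04 log units; within the scatter). Compound 4 is expected to give 9800 nM in this assay, with a likely range from 4500 nM to 21000 nM. The expected step, a 1.1-fold higher number from compound 2 to compound 4 (0.03 log units; within the scatter), is estimated to mirror the earlier one.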

Compound 4, half-maximal inhibitory concentration: 10600 nM
Beside the measured number, compound 4's estimate is 1.1-fold (0.03 log units) below it; the range from low to high includes it.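

In this assay, putting 4-fluorobenzyl in place of 4-fluorophenyl on the aromatic nitrogen of the second core gives a 1.2-fold higher number from compound 2 to compound 4 (0.07 log units; within the scatter), so here too the swap leaves the number within ordinary measurement noise. Set side by side, the two steps agree: the same change on two cores in this assay, a 1.1-fold higher number (0.04 log units; within the scatter) from compound 1 to compound 3 and a 1.2-fold higher number (0.07 log units; within the scatter) from compound 2 to compound 4, 1.1-fold (0.03 log units) apart, within the scatter of two such steps. This shows that, on these two cores, the swap carries over in the sense that neither number moves measurably, but it does not show that the swap would stay just as silent on a third core, and it says nothing about why the two groups give such similar numbers.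

Only 4-fluorophenyl and 4-fluorobenzyl appear on this nitrogen among the compounds shown, so it remains open how a longer chain, such as 2-phenylethyl, or a chain ending in an amine or a carboxylic acid, would behave there. Also open, going by these compounds, is whether the agreement between the two steps would hold in a different cell line.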